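The source may report more compounds than this note shows. Statements on the series, on what has been measured and on what is new or still open speak of the compounds shown alone.

Measured in a functional assay on MES-SA/Dx5 cells (Homo sapiens) for inhibition, with a stated time of 72 h; on this read-out higher numbers stand for weaker inhibition and lower numbers for stronger inhibition:
Compound 1 `CCOCc1cc(CN2CCCC2)c(O)c2ncccc12`: 912 nM
Compound 2 `COCc1cc(CN2CCC(C)CC2)c(O)c2ncccc12`: 575 nM

Compound 2, at 575 nM, lies within the usual scatter of compound 1, so the two numbers cannot be told apart. Compound 3 `CCOCc1cc(CN2CCC(C)CC2)c(O)c2ncccc12` is compound 2 with one change, (methyl in place of hydrogen on a saturated chain carbon bound to an oxygen on a saturated carbon), which turns methoxymethyl into ethoxymethyl. Among the measured compounds shown here, no measured pair shows this change alone, so no step beyond the scatter is expected in this assay, in either direction. Compound 1 also carries ethoxymethyl and gives 912 nM, though it differs elsewhere too. The estimated step of a 1.1-fold higher number from compound 2 to compound 3 (0.05 log units; within the scatter) stays within the scatter. Compound 3 is expected at 650 nM, with an estimated range of 300 nM to 1400 nM.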

Compound 3, half-maximal inhibitory concentration: 468 nM
The estimate for compound 3 lay 1.4-fold (0.14 log units) above the measured number; measured number inside the range.
By their numbers in this assay, from the lowest: compounds 3, 2 and 1 (each within the scatter of the next).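

In this assay the longer ether chain, ethoxymethyl in place of methoxymethyl, gives a 1.2-fold lower number from compound 2 to compound 3 (0.09 log units; within the scatter) and so the extra methyl on this saturated chain carbon leaves no readable mark. The swap of pyrrolidin-1-yl for 4-methylpiperidin-1-yl gives a 1.9-fold lower number from compound 1 to compound 3 (0.29 log units; within the scatter) and so it too cannot be told apart from repeat-measurement noise, even with both places differing from compound 1 to compound 2. No supporting measurement bears on these numbers.
As far as these compounds go, whether a longer chain such as butoxymethyl, or an amine or carboxylic acid on this chain, would shift the number remains open. So does the effect of a morpholin-4-yl ring on the other arm.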